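Chloro for trifluoromethyl in a flat cytotoxicity series

The compounds below may be only part of what the source reports. "The series", "measured", "known", "first", "only" and "open" are said of these compounds alone.

Values in an ADME assay on Vero cells (Chlorocebus sabaeus) for cytotoxicity, read by resazurin assay, with a stated time of 72 h (on this read-out lower numbers stand for stronger inhibition and higher numbers for weaker inhibition), are as follows
Compound 1 (`O=C(CCN1CCN(c2ccc(Cl)cc2)CC1)c1ccc(Br)cc1`) gives 52100 nM
Compound 2 (`O=C(CCN1CCN(c2ccc(Cl)cc2)CC1)c1ccc(C(F)(F)F)cc1`) gives 54200 nM
Compound 3 (`O=C(CCN1CCN(c2ccc(C(F)(F)F)cc2)CC1)c1ccc(OC(F)(F)F)cc1`) gives 64900 nM

Compound 3, at 64900 nM, lies within the scatter of both compound 1 and compound 2, so the three values cannot be told apart. The next compound is compound 4 (`O=C(CCN1CCN(c2ccc(Cl)cc2)CC1)c1ccc(OC(F)(F)F)cc1`), which has chloro in place of trifluoromethyl on an aromatic carbon, para to a large group (chloro in place of trifluoromethyl on an aromatic carbon). Among the measured compounds shown here, one measured step bears on this change, as it also exchanges groups on an aromatic carbon, here trifluoromethyl in place of bromo. That step is a 1.0-fold higher number from compound 1 to compound 2 (0.02 log units; within the scatter) and it stays within the scatter. Compound 1 and compound 2 also carry the chloro that compound 4 gains, and neither value stands apart from that of compound 3. No direction can be drawn from so few data, so no change beyond the scatter is expected in this assay here. The expected step is a 1.2-fold lower number from compound 3 to compound 4 (0.06 log units; within the scatter) and it is small. For compound 4 the estimated value is 56000 nM, with an expected range of 36000 nM to 88000 nM when measured.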

Compound 4, half-maximal inhibitory concentration: 95600 nM
Beside the measured number, compound 4's estimate is 1.7-fold (0.23 log units) below it, outside the stated range (above it).
By their numbers in this assay, from the lowest: compounds 1, 2, 3 and 4 (each within the scatter of the next).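

In this assay, moving from 4-(trifluoromethyl)phenyl to 4-chlorophenyl, para to a large group, gives a 1.5-fold higher number from compound 3 to compound 4 (0.17 log units; within the scatter) and so adds this exchange to those that stay within the scatter. With 4-chlorophenyl held constant, trifluoromethoxy in place of trifluoromethyl gives a 1.8-fold higher number from compound 2 to compound 4 (0.25 log units; within the scatter) and trifluoromethoxy in place of bromo gives a 1.8-fold higher number from compound 1 to compound 4 (0.26 log units; within the scatter) and these are the widest steps in the set, yet neither separates the compounds. No supporting measurement accounts for these values.

On these data alone, whether an amine or a carboxylic acid at the position para to a large group would give a step beyond the scatter remains open. As far as these compounds go, it is equally open whether a longer chain on the shared core would do so.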